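A few compounds are considered here, and "the series" means these few. Any claim that something is new, unique, unknown or untested is made for them only; others in the source may bear on it.

Measured so far in an ADME assay on microsomes from liver (Mus musculus) for metabolic stability, tested at 5 uM; on this read-out lower numbers stand for a shorter-lived compound and higher numbers for a longer-lived compound:
- compound 1 `CCCCCCCCNc1ccc(C(=O)O)cc1S(=O)(=O)N(C)C`: 0.217 h
- compound 2 `CN(C)S(=O)(=O)c1cc(C(=O)O)ccc1NCCCC(F)(F)F`: > 1 h

Compound 2 stands at > 1 h, which is a limit of this assay and not a number.

Compound 3 `CN(C)S(=O)(=O)c1cc(C(=O)O)ccc1NCCCCCC(F)(F)F` carries 3,3,3-trifluoropropyl in place of trifluoromethyl on a saturated chain carbon, three bonds along the chain from a nitrogen on an aromatic ring.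

Going by the values given here, the one measured step that bears on this is an at least 4.6-fold higher number from compound 1 to compound 2 (0.66 log units; beyond the scatter), with trifluoromethyl in place of pentyl at the same place. The new chain is longer than that of compound 2 and still ends in trifluoromethyl, so only part of that step is expected to be given back. The expected change is an at least 1.8-fold lower number from compound 2 to compound 3 (0.25 log units; that floor lies within the scatter), towards a lower number and modest in size. For compound 3 the estimate is 0.55 h, with an expected range of 0.22 h to 1.2 h.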

Compound 3, half-life: > 1 h
Compound 3 ended at the assay's limit; the forecaster's own chance of this, stated with the estimate: 30%; middle value at least 1.8-fold (0.25 log units) away from the limit.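

In this assay compound 3 gives > 1 h, which is a limit of the assay and not a number. At this place on the chain, 3,3,3-trifluoropropyl in place of trifluoromethyl still leaves the read-out clear of compound 1, with an at least 4.6-fold higher number from compound 1 to compound 3 (0.66 log units; beyond the scatter), so the gain seen with the shorter fluorinated chain does not depend on that shorter length alone. The step from compound 2 to compound 3 cannot be read, since both values are limits: the limit of > 1 h in this assay, at which 2 of the 3 values shown sit.

On these data alone, it remains open how far compound 2 and compound 3 lie past the limit, and so whether the added chain length costs any stability. Also open, as far as these compounds go, is whether a longer chain ending in trifluoromethyl keeps the gain, and how a chain ending in a hydroxyl group compares.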